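Trifluoromethyl to fluoro: a small expected step

The compounds below may be only part of what the source reports. "The series", "measured", "known", "first", "only" and "open" are said of these compounds alone.

Measured so far in a functional assay on CWR22R cells (Homo sapiens) for cytotoxicity, read by MTT assay, with a stated time of 72 h; a lower number here means a stronger inhibitor, a higher number a weaker inhibitor:
- compound 1 `CC1=CCCC(C)(C)C1/C=C/C(=O)/C=C/c1cccc(C(F)(F)F)c1` gives 2900 nM
- compound 2 `CC1=CCCC(C)(C)C1/C=C/C(=O)/C=C/c1cccc([N+](=O)[O-])c1` gives 4700 nM
- compound 3 `CC1=C(/C=C/C(=O)/C=C/c2ccc(C(F)(F)F)cc2)C(C)(C)CCC1O` gives 3200 nM

In this assay compound 3 at 3200 nM lies within the scatter of both other compounds, so repeat measurements alone could account for the gaps among these three numbers. The next compound, compound 4 `CC1=C(/C=C/C(=O)/C=C/c2ccc(F)cc2)C(C)(C)CCC1O`, keeps the core of compound 3 and carries fluoro in place of trifluoromethyl on an aromatic carbon. The counted change fluoro in place of trifluoromethyl on an aromatic carbon is confined to that one group.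

For the measured compounds named here, only one measured step bears on this. It also removes trifluoromethyl from an aromatic carbon, putting nitro there on a different core, and it came out as a 1.6-fold higher number from compound 1 to compound 2 (0.21 log units; within the scatter) in size. That is thin evidence, since it involves another incoming group and another core, but it gives no reason to expect a large shift. On these data alone, the step estimated here is a 1.2-fold higher number from compound 3 to compound 4 (0.07 log units; within the scatter) and is not expected to exceed the scatter, so its direction stays open. Compound 4 is expected at 3800 nM with 1800 nM to 8000 nM as the estimated range.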

Compound 4, half-maximal inhibitory concentration: 7500 nM
Beside the measured number, compound 4's estimate is 2.0-fold (0.30 log units) below it, within the range that was stated.
By their numbers in this assay, from the lowest: compounds 1, 3, 2 and 4 (each within the scatter of the next, the first and the last beyond it).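

In this assay the exchange of trifluoromethyl for fluoro on an aromatic carbon, para to a large group, gave a 2.3-fold higher number from compound 3 to compound 4 (0.37 log units; beyond the scatter) and this is the only step among the compounds shown that lies beyond the scatter. The effect is modest, but it shows that trifluoromethyl and fluoro are not interchangeable at this position on the core of compound 3, even though the two compounds differ only in this one group. No measurement shown here accounts for the higher number, so the result stands as an observation without an established cause.

The compounds shown compare only these two groups at this position on this core, so it remains open how a methoxy group, an amine or a carboxylic acid in the same place would compare with trifluoromethyl. On these data alone, it also remains open whether fluoro in place of trifluoromethyl would give a step of similar size on the core of compound 1, or whether this result holds only for the core of compound 3.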